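This account rests on a few compounds, and the source may have more. Where it says the series, first, only, none or still open, it means among the compounds named here.

Of the compounds shown here, three built on a shared core have been measured in a functional assay on A549 cells (Homo sapiens) for cytotoxicity, read by MTT assay, with a stated time of 48 h; a higher number here means a weaker inhibitor, a lower number a stronger inhibitor. Compound 1 (`Cn1c(=O)c2c(ncn2CC(=O)NCC(=O)OCc2cn(CC3OC(n4ccc(=O)[nH]c4=O)C4OC(C)(C)OC34)nn2)n(C)c1=O`) gives 5670 nM and compound 2 (`Cn1c(=O)c2c(ncn2CC(=O)OCc2cn(CC3OC(n4ccc(=O)[nH]c4=O)C4OC(C)(C)OC34)nn2)n(C)c1=O`) gives 3590 nM, two values within the usual scatter of each other. Compound 3 (`C#CCNC(=O)Cn1cnc2c1c(=O)n(C)c(=O)n2C`) is much smaller, and it gives 114000 nM. That is the highest number of the three, beyond the scatter from both of the others, which makes compound 3 the weakest inhibitor of the set.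

Compound 4 (`C#CCOC(=O)Cn1cnc2c1c(=O)n(C)c(=O)n2C`) has yet to be measured, and it departs from compound 3 in one place, with propargyloxy in place of propargylamino on a carbonyl carbon. Among the compounds with values here, no measured pair in the set differs in one place, so the data offer no direct guide to this exchange. Compound 4 shares the small size of compound 3 and lacks the large appendage of compound 1 and compound 2, so its number should stay close to that of compound 3, which gives 114000 nM. In this assay, no step beyond the scatter is expected, with only a slight lean toward a lower number. The expected change is a 1.4-fold lower number from compound 3 to compound 4 (0.15 log units; within the scatter). The estimated value for compound 4 is 80000 nM, within an expected range from 25000 nM to 200000 nM.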

Compound 4, half-maximal inhibitory concentration: 156000 nM
The estimate for compound 4 lay 2.0-fold (0.29 log units) below the measured number; low and high end bracket the measured number.
By their numbers in this assay, from the lowest: compounds 2 and 1 (each within the scatter of the next); then compounds 3 and 4 (each within the scatter of the next).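

In this assay, within the data shown here, the exchange of propargylamino for propargyloxy on a carbonyl carbon gives a 1.4-fold higher number from compound 3 to compound 4 (0.14 log units; within the scatter), and this is the first step in the set that can be read at a single place, since no earlier pair differed in one place only. At this position, then, going from propargylcarbamoyl to propargyloxycarbonyl takes away the hydrogen-bond donor of the propargylamino group and brings in a hydrogen-bond acceptor, yet the number stays within the scatter, so the read-out does not separate the amide from the ester in this small pair. No measurement is at hand that would explain this result or link it to any property of either group.

On these data alone, whether a carboxylic acid, a primary amide or a longer chain on this carbonyl carbon would also leave the number within the scatter remains open. Also open, as far as these compounds go, is whether the same exchange would stay as quiet in a compound carrying the large appendage seen in compound 1 and compound 2, as this single step speaks only for the small propargyl pair.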